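Alkynyl chain variation on the shared diaminopyrimidine series

The source may report more compounds than this note shows. Statements on the series, on what has been measured and on what is new or still open speak of the compounds shown alone.

Measured so far:
compound 1 `CCCCNc1nc(N)nc(C)c1C#CCN1CCCCC1`, 3790 nM
compound 2 `CCCCNc1nc(N)nc(C)c1CCCn1cccn1`, 1050 nM
compound 3 `CCCCNc1nc(N)nc(C)c1CCCn1ccc2ccccc21`, 1100 nM

In an assay on HEK293 cells for agonist activity at Toll-like receptor 8 (Homo sapiens), read by spectrophotometry (a lower number here means that less compound is needed, a higher number that more compound is needed for the effect), compound 1 gives the highest of the three numbers; compound 2 and compound 3 both sit clearly lower, beyond the scatter. Compound 4 `CCCC#Cc1c(C)nc(N)nc1NCCCC` has not yet been measured. It differs from compound 1 by ethyl in place of piperidin-1-yl on a saturated chain carbon bound to a triple-bonded carbon; the piperidin-1-yl group, with its one hydrogen-bond acceptor, is lost and a plain ethyl remains. Going by the values given here, no pair among the measured compounds isolates this change, so no step can be read off for it. The expected step of a 1.6-fold higher number from compound 1 to compound 4 (0.20 log units; within the scatter) is small, upward if anything, and not clearly beyond the scatter. For compound 4 an estimate of 6000 nM is given, ranging from 2000 nM to 20000 nM.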

Compound 4, half-maximal effective concentration: 5000 nM
For compound 4 the middle estimate is 1.2-fold (0.08 log units) above the measured one; the measured number falls inside the stated range.
By their numbers in this assay, from the lowest: compounds 2 and 3 (each within the scatter of the next); then compounds 1 and 4 (each within the scatter of the next).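

In this assay, this pair gives a 1.3-fold higher number from compound 1 to compound 4 (0.12 log units; within the scatter) for ethyl in place of piperidin-1-yl on a saturated chain carbon bound to a triple-bonded carbon. Removing the six-membered ring and its hydrogen-bond acceptor at this place therefore gives no change beyond the scatter. No evidence available here accounts for this result. Still open, on these data alone, is whether a primary amine, a carboxylic acid or a longer chain at this carbon would shift the number beyond the scatter. As far as these compounds go, the same exchange on a saturated chain also remains open.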